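The source may report more compounds than this note shows. Statements on the series, on what has been measured and on what is new or still open speak of the compounds shown alone.

Compound 3 `CSCC[C@H](NC(=O)CN(c1nc(Cl)nc2[nH]cnc12)C1CC1)C(=O)OCc1ccccc1` gives 22.2% in a functional assay on the whole organism (Tail, strain ICR) with Mus musculus as the target, in the tail flick test, with a stated time of 30 min, at a dose of 25 umol/kg by the oral route; a higher number here means a stronger effect of the compound at the dose given, a lower number a weaker effect. Within the data shown here, that is the lowest of the three numbers measured so far, although its gaps to compound 1 `N=C(N)NCCC[C@H](NC(=O)CN(c1nc(Cl)nc2[nH]cnc12)C1CC1)C(=O)OCc1ccccc1` at 23.2% and to compound 2 `NC(=O)C[C@H](NC(=O)CN(c1nc(Cl)nc2[nH]cnc12)C1CC1)C(=O)O` at 29.7% both lie within the scatter. Compound 4 `NC(=O)C[C@H](NC(=O)CN(c1nc(Cl)nc2[nH]cnc12)C1CC1)C(=O)OCc1ccccc1` has not yet been measured in this assay. It differs from compound 3 in one place: carbamoyl in place of (methylsulfanyl)methyl on a saturated chain carbon, two bonds along the chain from an amide-type nitrogen and a carbonyl carbon. Among the measured compounds shown here, the only measured step at this part of the chain, a number 1 percentage points lower from compound 1 to compound 3 (within the scatter), stayed within the scatter, and compound 2, which already carries the carbamoylmethyl chain, also sits within the scatter of compound 3. No step beyond the scatter is therefore expected in this assay. The expected step is a number 3.8 percentage points higher from compound 3 to compound 4 (within the scatter). For compound 4 the estimate is 26%, with a range from 17% to 35%.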

Compound 4, a percentage reported as activity, at one dose (the size of the read-out at that dose, not a potency): 24.4%
Compound 4: middle estimate off by 1.6 percentage points, on the high side, within the range that was stated.
By their numbers in this assay, from the lowest: compounds 3, 1, 4 and 2 (each within the scatter of the next).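

In this assay the carbamoyl chain gives no separable change at this position: a number 2.2 percentage points higher from compound 3 to compound 4 (within the scatter) and a number 1.2 percentage points higher from compound 1 to compound 4 (within the scatter). Three different chains on the same benzyl-bearing scaffold therefore remain within the scatter of one another. Among these compounds, the first reading of the other site shows that benzyl in place of hydrogen on an oxygen next to a carbonyl group also stays within the scatter, with a number 5.3 percentage points lower from compound 2 to compound 4 (within the scatter). No available evidence bears on this result. As far as these compounds go, whether an amine, a carboxylic acid or a longer chain on this saturated chain carbon would give a step beyond the scatter remains open.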